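The source may report more compounds than this note shows. Statements on the series, on what has been measured and on what is new or still open speak of the compounds shown alone.

Working notes on the series in a functional assay on CHO cells for antagonist activity at Orexin receptor type 2 (Homo sapiens), read by FLIPR and calcium flux; on this read-out lower numbers stand for stronger inhibition and higher numbers for weaker inhibition.

Compound 1 `CCn1nc(C)c2c1CCN(C(C(=O)NC)c1ccccc1)C2CCc1ccccc1F` gives 22 nM in this assay. Compound 2 `CCn1nc(C)c2c1CCN(C(C(=O)NC)c1ccccc1)C2CCc1cccc(F)c1` gives 10 nM, and compound 3 `CCn1nc(C)c2c1CCN([C@@H](C(=O)NC)c1ccccc1)[C@H]2COc1ccc(C)cc1` gives 19 nM. Compound 2 sits at the low end of the three numbers: the gap to compound 3 is within the scatter, so no order between those two is claimed, whereas the gap to compound 1 is beyond it, as the step of a 2.2-fold lower number from compound 1 to compound 2 (0.34 log units; beyond the scatter) records for the move of the fluoro from one aromatic position to another on the phenyl of the side chain.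

Compound 4 `CCn1nc(C)c2c1CCN(C(C(=O)NC)c1ccccc1)C2CCc1cccc(C)c1` differs from compound 2 only in methyl in place of fluoro on an aromatic carbon. For the measured compounds named here, no measured pair shows this exchange of fluoro for methyl; the only step in hand, a 2.2-fold lower number from compound 1 to compound 2 (0.34 log units; beyond the scatter), concerns the position of a fluoro, not its replacement, and bears on the change from compound 2 to compound 4 only loosely. With nothing else to go on, the expected step of a 1.1-fold higher number from compound 2 to compound 4 (0.04 log units; within the scatter) is none beyond the scatter. Compound 4 is therefore estimated at 11 nM, with a range from 4 nM to 32 nM.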

Compound 4, half-maximal inhibitory concentration: 19 nM
Beside the measured number, compound 4's estimate is 1.7-fold (0.24 log units) below it, and the stated range covers the measured number.
By their numbers in this assay, from the lowest: compounds 2, 3, 4 and 1 (each within the scatter of the next, the first and the last beyond it).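

In this assay, for the compounds shown here, the first reading of an exchange of fluoro for methyl on this aromatic carbon does not separate the two groups (a 1.9-fold higher number from compound 2 to compound 4 (0.28 log units; within the scatter)), so no order between compound 2 and compound 4 is claimed. Changing both the group and its place on the phenyl of the side chain, 3-methylphenyl in place of 2-fluorophenyl, also stays within the scatter (a 1.2-fold lower number from compound 1 to compound 4 (0.06 log units; within the scatter)), whereas only the move of the fluoro goes beyond it (a 2.2-fold lower number from compound 1 to compound 2 (0.34 log units; beyond the scatter)). No measurement at hand accounts for these numbers.

On these data alone, whether chloro, methoxy or trifluoromethyl on this aromatic carbon would read apart from fluoro and methyl remains open. Also open, as far as these compounds go, is how methyl would read on the other aromatic carbons of this phenyl.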